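Swapping a benzyl arm for a methoxyphenyl ethyl arm

The source may hold more compounds than are shown below. What is called first, only, known or untested is meant among the compounds shown, and "the series" means these compounds.

Three compounds sharing one core were tested in a toxicity assay on MDCK cells (Canis lupus familiaris) for cytotoxicity, read by crystal violet staining, with a stated time of 48 h; a higher number here means that more compound is tolerated, a lower number that less compound is tolerated. Compound 1 `CCc1ccc(CN(Cc2ccc(F)cc2)Cc2cc3ccc(C)cc3[nH]c2=O)cc1` gives > 33000 nM in this assay, a limit rather than a number. Compound 2 `CCc1ccc2[nH]c(=O)c(CN(Cc3ccc(C(C)(C)C)cc3)Cc3ccc(F)c(F)c3)cc2c1` likewise gives > 33000 nM, again only a limit. Compound 3 `Cc1ccc2[nH]c(=O)c(CN(Cc3ccc(F)cc3)Cc3ccc(-c4ccccc4)cc3)cc2c1` gives > 5000 nM, which is also a limit. So compound 2 stands at the limit of > 33000 nM in this assay, at which 2 of the 3 values shown sit, while compound 3 sits at the limit of > 5000 nM in this assay, at which 1 of the 3 values shown sits; none of the three has been given a number, only a floor that it clears.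

Compound 4 `CCc1ccc2[nH]c(=O)c(CN(Cc3ccc(C(C)(C)C)cc3)[C@@H](C)c3ccc(OC)cc3)cc2c1` differs from compound 2 at one place: 1-(4-methoxyphenyl)ethyl in place of 3,4-difluorobenzyl on an amine nitrogen. Within the data shown here, no measured pair in this set shows what such a swap does, so the expectation rests on the three limits alone. Compound 4 is expected to behave like the others, with a step from compound 2 to compound 4 of a step that the limit leaves unreadable from compound 2 to compound 4 that is most likely within the scatter, so that the assay again reports only a limit. Compound 4 is estimated at 40000 nM in this assay, with a likely range from 15000 nM to 100000 nM.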

Compound 4, half-maximal cytotoxic concentration: > 5000 nM
Compound 4 ended at the assay's limit (the forecaster's own chance of this, stated with the estimate: 75%); the middle value does not contradict the limit.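

Compound 2 and compound 4 are each reported only as a limit, so the step between them cannot be read. The compounds shown leave open whether 1-(4-methoxyphenyl)ethyl in place of 3,4-difluorobenzyl on the amine nitrogen changes how much compound is tolerated in this assay.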